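A few compounds are considered here, and "the series" means these few. Any claim that something is new, unique, unknown or untested is made for them only; others in the source may bear on it.

Measured in an in vitro ADME assay on microsomes from liver (Simiiformes); a lower number here means that the compound disappears faster, a higher number that the compound lasts longer:

Compound 1 `Cc1cc(-c2noc(C3CC3)n2)cc(C)c1OCCCc1cc(C2CC2)no1`: > 2.5 h
Compound 2 `Cc1cc(-c2noc(C(F)(F)F)n2)cc(C)c1OCCCc1cc(CO)no1`: > 2.5 h

Neither entry is a number. On these data alone, compound 2 gives > 2.5 h, which is a limit of the assay, so its true half-life remains unknown. Compound 1 gives > 2.5 h, which is also a limit. The two compounds therefore share one reading: the limit of > 2.5 h in this assay, at which 2 of the 2 values shown sit.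

Compound 3 `Cc1cc(-c2noc(C3CC3)n2)cc(C)c1OCCCc1cc(CO)no1` has cyclopropyl in place of trifluoromethyl on an aromatic carbon, turning the 5-(trifluoromethyl)-1,2,4-oxadiazol-3-yl of compound 2 into 5-cyclopropyl-1,2,4-oxadiazol-3-yl (cyclopropyl in place of trifluoromethyl on an aromatic carbon). Compound 1 carries that same cyclopropyl group and still reads > 2.5 h, so no marked loss is expected. Within the data shown here, no measured step gauges this change, and no shift beyond the scatter is expected in this assay, in either direction. The expected change is a step that the limit leaves unreadable from compound 2 to compound 3. For compound 3 the estimated half-life is 3 h, with an expected range of 1.5 h to 6 h.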

Compound 3, half-life: > 2.5 h
Compound 3 was reported as a limit; the forecaster's own chance of this, stated with the estimate: 65%; the middle value does not contradict the limit.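

No step from compound 1 or compound 2 to compound 3 can be read, since all three compounds share one reading: the limit of > 2.5 h in this assay, at which 3 of the 3 values shown sit.

The compounds shown leave open the true half-life of each, and whether either exchange, cyclopropyl for trifluoromethyl or hydroxymethyl for cyclopropyl, changes it at all.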